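The source may hold more compounds than are shown below. What is called first, only, known or untested is meant among the compounds shown, and "the series" means these compounds.

Measured so far in a functional assay on Shh Light II cells (Mus musculus) for inhibition, read by a luciferase reporter; a higher number here means a weaker inhibitor, a lower number a stronger inhibitor:
- compound 1 `O=C(NC1CCCCC1)N1CCN(c2nc(-c3ccc4ccccc4n3)no2)CC1`: 53 nM
- compound 2 `O=C(CC1CCCCCC1)N1CCC(c2nc(-c3ccc4ccccc4n3)no2)CC1`: 840 nM

Compound 2 carries the higher of the two numbers, and its gap to compound 1 lies beyond the scatter. The next structure is compound 3 `O=C(N1CCC(c2nc(-c3ccc4ccccc4n3)no2)CC1)N1CCCc2ccccc21`, which is reached from compound 2 by one change: 1,2,3,4-tetrahydroquinolin-1-yl in place of cycloheptylmethyl on a carbonyl carbon. In words, 1,2,3,4-tetrahydroquinolin-1-yl stands in place of cycloheptylmethyl on a carbonyl carbon. Going by the values given here, no measured step isolates this change, so any forecast rests on thin evidence. Compound 1 also has a nitrogen on its carbonyl carbon and reads 53 nM, although it differs from compound 3 elsewhere too. On that single comparison, a moderately lower number in this assay is expected relative to compound 2 at 840 nM, with a step somewhat beyond the scatter and a real chance of none. The expected change is a 3.4-fold lower number from compound 2 to compound 3 (0.53 log units; beyond the scatter). For compound 3 the estimated value is 250 nM, with an expected range from 60 nM to 1000 nM.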

Compound 3, half-maximal inhibitory concentration: 2300 nM
Beside the measured number, compound 3's estimate is 9.2-fold (0.96 log units) below it, and the stated range ends below it.
By their numbers in this assay, from the lowest: compound 1; then compound 2; then compound 3.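

In this assay, the substituent on a carbonyl carbon whose other neighbours are an amide-type nitrogen in a ring affects the read-out: swapping cycloheptylmethyl for 1,2,3,4-tetrahydroquinolin-1-yl gives (a 2.7-fold higher number from compound 2 to compound 3 (0.44 log units; beyond the scatter)), a modest move toward weaker inhibition. On the core shared by compound 2 and compound 3, a ring nitrogen on this carbonyl carbon therefore does not by itself give a stronger inhibitor, at least when that nitrogen belongs to 1,2,3,4-tetrahydroquinolin-1-yl. No supporting measurement bears on this step, so it stands without an explanation.

The step changes the ring system and the atom on the carbonyl carbon together, so the contributions of the nitrogen and the six-membered aromatic ring remain unseparated; a piperidin-1-yl group at the same place would keep a ring nitrogen there without the aromatic ring. Compound 1 differs from compound 2 and compound 3 in more than one place, so its lower number cannot be assigned to any single structural change.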